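This account rests on a few compounds, and the source may have more. Where it says the series, first, only, none or still open, it means among the compounds named here.

In a functional assay on ZR-75-1 cells (Homo sapiens) for inhibition, read by sulforhodamine B assay (a lower number here means a stronger inhibitor of growth, a higher number a weaker inhibitor of growth), compound 1 (`COc1ccc(-c2ccc(-c3ccc(-c4nc5ccccc5[nH]4)cc3)cc2)cc1`) gives 35100 nM and compound 2 (`Oc1cccc2[nH]c(-c3ccc(-c4ccc(-c5ccc(C(F)(F)F)cc5)cc4)cc3)nc12`) gives 5110 nM in the same read-out. Compound 3 (`Oc1cccc2[nH]c(-c3ccc(-c4ccc(-c5ccc(OC(F)(F)F)cc5)cc4)cc3)nc12`) gives 3800 nM and so sits level with compound 2, clearly under compound 1. The change to compound 4 (`COc1ccc(-c2ccc(-c3ccc(-c4nc5c(O)cccc5[nH]4)cc3)cc2)cc1`) is trifluoromethoxy to methoxy, that is methyl in place of trifluoromethyl on an oxygen on an aromatic ring. Among the measured compounds shown here, the one measured step on a related group, a 1.3-fold lower number from compound 2 to compound 3 (0.13 log units; within the scatter) for trifluoromethoxy in place of trifluoromethyl, stays small. For the measured compounds named here, no measured step covers this exact swap, so the read-across is weak and no shift beyond the scatter is expected in this assay here. The expected step is a 1.2-fold higher number from compound 3 to compound 4 (0.07 log units; within the scatter) on this estimate. Compound 4 is estimated at 4500 nM with an expected range of 1800 nM to 12000 nM in this series.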

Compound 4, concentration for 50% growth inhibition: 8200 nM
Compound 4: the middle estimate sits 1.8-fold (0.26 log units) below what was measured, within the range that was stated.
By their numbers in this assay, from the lowest: compounds 3, 2 and 4 (each within the scatter of the next, the first and the last beyond it); then compound 1.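

Methyl in place of trifluoromethyl on the oxygen gives the first step here beyond the scatter at this position: a 2.2-fold higher number from compound 3 to compound 4 (0.33 log units; beyond the scatter) in this assay is modest, while a 1.6-fold higher number from compound 2 to compound 4 (0.21 log units; within the scatter) stays within the scatter. The position therefore tolerates these three groups with only modest movement. The first matched read on the hydroxy in place of hydrogen on an aromatic carbon is a 4.3-fold lower number from compound 1 to compound 4 (0.63 log units; beyond the scatter) and is also modest.

Open, going by these compounds, is whether an amine or a carboxylic acid at this position would keep growth inhibition, and whether the hydroxy step holds with trifluoromethyl or trifluoromethoxy in place of methoxy. No measured evidence bears on the origin of these steps.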